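The compounds below may be only part of what the source reports. "The series", "measured", "known", "first", "only" and "open" are said of these compounds alone.

Measured so far in a functional assay on the whole organism (strain Kunming) with Mus musculus as the target, with a stated time of 0.5 h; a higher number here means that more compound is needed for the effect, a lower number that less compound is needed:

- Compound 1 `COc1cc(OC)c(OC)cc1/C=C/COC(=O)/C=C/c1ccc(Br)cc1`: 61.8 mg/kg
- Compound 2 `COc1cc(OC)c(OC)cc1/C=C/COC(=O)/C=C/c1ccccc1C(F)(F)F`: 85.7 mg/kg
- Compound 3 `COc1cc(OC)c(OC)cc1/C=C/COC(=O)/C=C/c1ccccc1Cl`: 58.7 mg/kg

These three compounds share a core and differ only in the aromatic group at one end of the molecule. Compound 3, at 58.7 mg/kg, cannot be told apart from the other two, since its value lies within the usual scatter of both.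

Compound 4 `COc1cccc(/C=C/C(=O)OC/C=C/c2cc(OC)c(OC)cc2OC)c1` keeps the shared core but carries 3-methoxyphenyl in place of 2-chlorophenyl on a double-bonded chain carbon bound to a double-bonded chain carbon.

All three measured steps bear on this change. Each alters the aromatic group at this same place. They are a 1.1-fold lower number from compound 1 to compound 3 (0.02 log units; within the scatter), a 1.4-fold higher number from compound 1 to compound 2 (0.14 log units; within the scatter) and a 1.5-fold lower number from compound 2 to compound 3 (0.16 log units; within the scatter). Each of them stays within the scatter, so this position has so far shown little response in this assay. Going by the values given here, none of the measured compounds carries 3-methoxyphenyl, however, so the new group itself remains untested and the range has to stay wide.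

No step beyond the scatter is expected, and the expected change is a 1.1-fold higher number from compound 3 to compound 4 (0.04 log units; within the scatter). Compound 4 is estimated at 65 mg/kg, with an expected range from 35 mg/kg to 120 mg/kg.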

Compound 4, dose for half-maximal effect: 72.9 mg/kg
Estimate against measurement, compound 4: 1.1-fold (0.05 log units) below, and the stated range covers the measured number.
By their numbers in this assay, from the lowest: compounds 3, 1, 4 and 2 (each within the scatter of the next).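

In this assay, going by these compounds alone, 3-methoxyphenyl brings an oxygen to this place for the first time, yet every comparison with the earlier groups stays within the scatter: there is a 1.2-fold higher number from compound 3 to compound 4 (0.09 log units; within the scatter) and a 1.2-fold higher number from compound 1 to compound 4 (0.07 log units; within the scatter), while the remaining comparison shows a 1.2-fold lower number from compound 2 to compound 4 (0.07 log units; within the scatter). The four aromatic groups shown, 4-bromophenyl, 2-(trifluoromethyl)phenyl, 2-chlorophenyl and 3-methoxyphenyl, therefore cannot be told apart here, even though their substituents differ in kind and their names put those substituents at different ring positions. No measurement at hand offers an explanation for this flat response.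

On these data alone, it remains open whether a group of a quite different kind at this place, such as a phenyl ring carrying an amine or a carboxylic acid, or a longer alkyl chain in place of the aromatic ring, would move the number beyond the scatter. Also open, as far as these compounds go, is whether 2-methoxyphenyl or 4-methoxyphenyl would behave like 3-methoxyphenyl, or whether the response of this position is less flat than these four compounds suggest.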